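The compounds below may be only part of what the source reports. "The series", "measured", "known", "first", "only" and "open" are said of these compounds alone.

- compound 1 `Sc1nnc(-c2ccc3c(c2)OCCO3)n1-c1ccccc1` gives 51900 nM
- compound 2 `c1ccc(CSc2nnc(-c3ccc4c(c3)OCCO4)n2-c2ccccc2)cc1` gives 32800 nM

For the measured compounds named here, in a functional assay on HeLa cells (Homo sapiens) for antiproliferative activity, read by MTT assay, with a stated time of 24 h (a lower number here means a stronger inhibitor, a higher number a weaker inhibitor), compound 1 gives 51900 nM and stands level with compound 2, the only other measured compound, since the two numbers lie within the scatter of each other. Compound 3 `Clc1ccccc1CSc1nnc(-c2ccc3c(c2)OCCO3)n1-c1ccccc1` has not yet been measured. It has 2-chlorobenzyl in place of hydrogen on a sulfur of compound 1 (2-chlorobenzyl in place of hydrogen on a sulfur). Going by the values given here, only one measured step bears on this change, and it places plain benzyl on the same sulfur (a 1.6-fold lower number from compound 1 to compound 2 (0.20 log units; within the scatter)). Among the compounds with values here, that step stays within the scatter, and no measured compound shows what the chlorine adds on its own. No step beyond the scatter is therefore expected in this assay, only a possible slight drift towards a lower number. The estimated step is small (a 1.7-fold lower number from compound 1 to compound 3 (0.24 log units; within the scatter)). Compound 3 is expected at 30000 nM in a range from 12000 nM to 70000 nM as an estimate.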

Compound 3, half-maximal inhibitory concentration: 29000 nM
Estimate against measurement, compound 3: 1.0-fold (0.01 log units) above; the range from low to high includes it.
By their numbers in this assay, from the lowest: compounds 3, 2 and 1 (each within the scatter of the next).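

In this assay, 2-chlorobenzyl in place of hydrogen on the sulfur gives a 1.8-fold lower number from compound 1 to compound 3 (0.25 log units; within the scatter), and chloro in place of hydrogen on an aromatic carbon gives a 1.1-fold lower number from compound 2 to compound 3 (0.05 log units; within the scatter). For the compounds shown here, the second step isolates the chlorine for the first time, and, like the step for the whole 2-chlorobenzyl group, it stays within the usual scatter, so this assay cannot separate compound 1, compound 2 and compound 3. Nothing measured here offers an explanation for how close these numbers lie.

Going by these compounds, it remains open whether a group of another kind on this sulfur, such as a carboxylic acid or a longer chain ending in an amine, would give a step beyond the scatter. The effect of a nitro or methoxy group on the benzyl ring is also unknown.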